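The source may hold more compounds than are shown below. What is called first, only, known or untested is meant among the compounds shown, and "the series" means these compounds.

Measured compounds:
Compound 1 `CC1OC(n2c(=O)n(C)c3c(O)nc(N)nc32)[C@H](O)[C@@H]1O` gives 0% in a functional assay on the whole organism (B cells) with Mus musculus as the target; a higher number here means a larger maximal response, a lower number a smaller maximal response.
Compound 2 `[N-]=[N+]=NCC(O)Cn1c(=O)n(C2OC(CO)[C@@H](O)[C@H]2O)c2nc(N)nc(O)c21` gives 91% in this assay.
Compound 3 `C=CCn1c(=O)n(CCCC)c2nc(N)nc(O)c21` gives 77% in this assay.

Among these three, compound 2 stands highest in this assay. Its nearest neighbour is compound 3, whose value lies lower by a gap beyond the usual scatter of repeated measurements, and compound 1 lies far below, with no measurable response at all. No two of these compounds differ in a single place, so no direct step between measured values can be read off; only the three numbers themselves are known.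

The step followed here leads from compound 2 to compound 4 `Nc1nc(O)c2c(n1)n(C1OC(CO)[C@@H](O)[C@H]1O)c(=O)n2Cc1ccccc1`, which has not yet been measured in this assay. The change is this: phenyl in place of 2-azido-1-hydroxyethyl on a saturated chain carbon bound to an aromatic nitrogen. The group that leaves carries hydrogen-bond donors and acceptors and an azide; the group that enters is a plain six-membered aromatic ring of carbon only, on the same saturated chain carbon bound to an aromatic nitrogen.

Without a measured pair that shares this change, the size of the step is uncertain. Compound 3, which carries simple hydrocarbon chains on both aromatic nitrogens, still gives 77%, so a substantial response with a hydrocarbon group at this place is plausible, while compound 1 shows that the response can also vanish. Compound 4 is therefore expected to give 72% in this assay, within a range from 40% to 100%. This estimate corresponds to a downward step a number 19 percentage points lower from compound 2 to compound 4 (beyond the scatter) that is expected to lie somewhat beyond the scatter, though a result within the scatter of compound 2 would not be surprising.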

Compound 4, largest response reached (reported as maximal response), in percent of the reference or control that the assay uses: 110%
Compound 4: middle estimate off by 38 percentage points, on the low side; the whole stated range lies below it.
By their numbers in this assay, from the lowest: compound 1; then compound 3; then compound 2; then compound 4.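

In this assay, within the data shown here, placing phenyl in place of 2-azido-1-hydroxyethyl on a saturated chain carbon bound to an aromatic nitrogen brings the response out a number 19 percentage points higher from compound 2 to compound 4 (beyond the scatter), the first step in this set that can be read between two compounds differing in one place. The position therefore keeps its full response without the azide and the hydroxyl of the group that leaves: with benzyl in place of 3-azido-2-hydroxypropyl, compound 4 gives 110%, so this exchange raises the maximal response rather than lowering it. No measurement at hand bears on why the response changes in this way.

This single pair changes the azide, the hydroxyl and the aromatic ring all at once, so it leaves open which of these differences carries the step. A cyclohexyl group on the same saturated chain carbon, a phenyl ring bearing a methoxy group or a fluorine, or a longer chain such as 2-phenylethyl would show whether the aromatic ring itself matters and how much room for change this position allows.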